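A few compounds are considered here, and "the series" means these few. Any claim that something is new, unique, unknown or untested is made for them only; others in the source may bear on it.

In a functional assay on MDA-MB-231 cells (Homo sapiens) for antiproliferative activity, read by MTT assay, with a stated time of 48 h (on this read-out lower numbers stand for stronger inhibition and higher numbers for weaker inhibition), the measured compounds stand as follows:
compound 1 `O=C(Nc1cc(Sc2ncn[nH]2)c(O)c2ccccc12)c1ccc([N+](=O)[O-])cc1` gives > 100000 nM;
compound 2 `Cc1nnc(Sc2cc(NC(=O)c3ccc(Cl)cc3)c3ccccc3c2O)s1` gives > 100000 nM.

For compound 1 this assay reports only a limit, not a number. The same holds for compound 2 in this assay. Both sit at the limit of > 100000 nM in this assay, at which 2 of the 2 values shown sit, so compound 1 stands at the limit itself. Compound 3 `O=C(/C=C/c1ccc(Cl)cc1)Nc1cc(Sc2ncn[nH]2)c(O)c2ccccc12` differs from compound 1 by 2-(4-chlorophenyl)ethenyl in place of 4-nitrophenyl on a carbonyl carbon. For the measured compounds named here, no step between measured compounds is available to size this change; the expected step of an at least 2.5-fold lower number from compound 1 to compound 3 (0.39 log units; beyond the scatter) is taken as a modest gain beyond the scatter. Compound 3 is therefore estimated at 40000 nM, within 8000 nM to 200000 nM.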

Compound 3, half-maximal inhibitory concentration: > 100000 nM
Compound 3: no number, only a limit (the forecaster's own chance of this, stated with the estimate: 45%); middle value at least 2.5-fold (0.39 log units) away from the limit.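

In this assay, for the compounds shown here, compound 3 gives > 100000 nM which is only a limit, as is the result for compound 1, so no step between these two compounds can be read. As far as these compounds go, whether 2-(4-chlorophenyl)ethenyl in place of 4-nitrophenyl changes inhibition at all remains open.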